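Phenyl in place of acetyl on the ring amine nitrogen

This account rests on a few compounds, and the source may have more. Where it says the series, first, only, none or still open, it means among the compounds named here.

Compound 1 `CC(=O)N1CCN(c2nc(Nc3ccc(C#N)c(C(F)(F)F)c3)nc(Oc3ccnc4ccccc34)n2)CC1` bears an acetyl on an amine nitrogen in a ring. In a functional assay on DU-145 cells (Homo sapiens) for cytotoxicity, read by sulforhodamine B assay, with a stated time of 48 h (a lower number here means that less compound is tolerated, a higher number that more compound is tolerated), compound 1 reaches only the limit of the assay, > 100000 nM. Compound 2 `COc1ccc(N2CCN(c3nc(Nc4ccc(C#N)c(C(F)(F)F)c4)nc(Oc4ccnc5ccccc45)n3)CC2)cc1` carries 4-methoxyphenyl in the same place; in this assay compound 2 likewise stops at the limit, > 100000 nM. Compound 3 `CC(C)N1CCN(c2nc(Nc3ccc(C#N)c(C(F)(F)F)c3)nc(Oc3ccnc4ccccc34)n2)CC1` carries isopropyl there, and in this assay compound 3 again gives no more than the limit, > 100000 nM. Going by the values given here, the three steps between these compounds, a step that the two limits leave unreadable from compound 1 to compound 2, a step that the two limits leave unreadable from compound 1 to compound 3 and a step that the two limits leave unreadable from compound 2 to compound 3, cannot be sized because the limit of > 100000 nM in this assay, at which 3 of the 3 values shown sit, holds every value so far. Nothing in this set has yet produced a readable number.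

Compound 4 `N#Cc1ccc(Nc2nc(Oc3ccnc4ccccc34)nc(N3CCN(c4ccccc4)CC3)n2)cc1C(F)(F)F` differs from compound 1 by phenyl in place of acetyl on an amine nitrogen in a ring. Of the measured changes, the one to 4-methoxyphenyl is the nearest in kind, and it, like the others, left the read-out at the limit. On that basis compound 4 is expected to remain at the limit as well, with the estimated step that the limit leaves unreadable from compound 1 to compound 4 expected to be unreadable rather than a shift beyond the scatter. The expected value for compound 4 in this assay is estimated at 150000 nM, within a range from 60000 nM to 400000 nM.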

Compound 4, concentration lethal to 50% of the cells: > 100000 nM
Compound 4 ended at the assay's limit (the forecaster's own chance of this, stated with the estimate: 85%); the middle value is on the limit's open side.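

With compound 4 added, the steps joining it to compound 1, compound 2 and compound 3 cannot be read, because all the values shown sit at one limit: the limit of > 100000 nM in this assay, at which 4 of the 4 values shown sit.

The compounds shown leave open whether any group on the ring amine nitrogen of this shared core can give a readable value in this assay.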